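The compounds below may be only part of what the source reports. "The series", "measured", "known", "first", "only" and "open" are said of these compounds alone.

Series notes. Compound 1 `OCc1ccc(-c2nn(Cc3cccnc3)c3ccccc23)o1` and compound 2 `CC(C)c1cnc(-c2nn(Cc3ccccc3F)c3ncccc23)nc1N` differ in more than one place, so only their numbers are set side by side. In a functional assay (aorta) with Oryctolagus cuniculus as the target (on this read-out lower numbers stand for stronger inhibition and higher numbers for weaker inhibition), compound 1 gives 9600 nM, while in this assay compound 2 gives 207000 nM, the higher of the two values, with the gap between compound 1 and compound 2 lying beyond the scatter. Compound 3 `CC(C#N)CCCCCc1cnc(-c2nn(Cc3ccccc3F)c3ncccc23)nc1N` departs from compound 2 by 6-cyanoheptyl in place of isopropyl on an aromatic carbon. Within the data shown here, no measured pair shows the effect of this change, so no step beyond the scatter is expected; a 1.4-fold lower number from compound 2 to compound 3 (0.14 log units; within the scatter) is the estimated step. Compound 3 is expected to give about 150000 nM in this assay, within 30000 nM to 700000 nM.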

Compound 3, half-maximal inhibitory concentration: 1290000 nM
The estimate for compound 3 lay 8.6-fold (0.93 log units) below the measured number; the whole stated range lies below it.
By their numbers in this assay, from the lowest: compound 1; then compound 2; then compound 3.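

Among these compounds, the change from isopropyl to 6-cyanoheptyl on this aromatic carbon, ortho to the amino group, gives the first one-place comparison: in this assay it is a 6.2-fold higher number from compound 2 to compound 3 (0.79 log units; beyond the scatter). The position therefore does respond to its substituent, and this longer nitrile-bearing chain gives weaker inhibition than isopropyl. Nothing at hand explains the loss. The compounds shown leave open whether the chain length or the nitrile accounts for the step. A plain heptyl chain, or a shorter chain ending in an amine, would separate the two.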